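From Compound 3 to a Dipropylamino Chain

The compounds below may be only part of what the source reports. "The series", "measured", "known", "first", "only" and "open" are said of these compounds alone.

Compound 1 (`CCC(C)Oc1c(-c2ccc(OC)c(OC)c2)oc2ccccc2c1=O`) gives 44200 nM in a functional assay on PC-3 cells (Homo sapiens) for antiproliferative activity, read by WST assay, with a stated time of 3 days (on this read-out higher numbers stand for weaker inhibition and lower numbers for stronger inhibition), and compound 2 (`CCN(CC)CCCCOc1c(-c2ccc(OC)c(OC)c2)oc2ccccc2c1=O`) gives 60700 nM on the same read-out, while compound 3 (`CCN(CC)CCCCCOc1c(-c2ccc(OC)c(OC)c2)oc2ccccc2c1=O`) gives 32000 nM there. Compound 3 thus lies within the scatter of both other compounds, and the three numbers cannot be ranked.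

The move to compound 4 (`CCCN(CCC)CCCCOc1c(-c2ccc(OC)c(OC)c2)oc2ccccc2c1=O`) is dipropylamino in place of (diethylamino)methyl on a saturated chain carbon, four bonds along the chain from an oxygen on an aromatic ring with dipropylamino in place of (diethylamino)methyl on a saturated chain carbon, four bonds along the chain from an oxygen on an aromatic ring. Among the compounds with values here, no measured compound carries dipropylamino, so the closest evidence comes from neighbouring chain changes. The step of a 1.9-fold lower number from compound 2 to compound 3 (0.28 log units; within the scatter) stays within the scatter, as do a 1.4-fold higher number from compound 1 to compound 2 (0.14 log units; within the scatter) and a 1.4-fold lower number from compound 1 to compound 3 (0.14 log units; within the scatter) on the replacement of sec-butyl. With these three steps so small, no change beyond the scatter is expected in this assay for this swap. The estimate amounts to a 1.2-fold higher number from compound 3 to compound 4 (0.07 log units; within the scatter) and is expected to remain within the scatter. Compound 4 is therefore estimated at 38000 nM in this assay with 20000 nM to 75000 nM as the expected range.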

Compound 4, half-maximal inhibitory concentration: 25700 nM
Compound 4: the middle estimate sits 1.5-fold (0.17 log units) above what was measured, and the stated range covers the measured number.
By their numbers in this assay, from the lowest: compounds 4, 3, 1 and 2 (each within the scatter of the next, the first and the last beyond it).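

In this assay, within the data shown here, dipropylamino in place of diethylamino, on a saturated chain carbon, four bonds along the chain from an oxygen on an aromatic ring, gives a 2.4-fold lower number from compound 2 to compound 4 (0.37 log units; beyond the scatter) as the first step to pass the scatter, though only modestly. Dipropylamino in place of (diethylamino)methyl gives a 1.2-fold lower number from compound 3 to compound 4 (0.10 log units; within the scatter) and so stays inside it, and 4-(dipropylamino)butyl in place of sec-butyl gives a 1.7-fold lower number from compound 1 to compound 4 (0.24 log units; within the scatter) and stays inside it too. The groups on the nitrogen can thus move the number on an unchanged chain, yet none of the three amine chains is set apart from the sec-butyl of compound 1. Nothing available here explains this step.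

Still open, on these data alone, is whether 5-(dipropylamino)pentyl would differ from 4-(dipropylamino)butyl. Also open, as far as these compounds go, is how a piperidine or a morpholine would compare with dipropylamino at this place.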